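Aryl swap transferred to a second thiourea core

The source may report more compounds than this note shows. Statements on the series, on what has been measured and on what is new or still open speak of the compounds shown alone.

Compound 1 `COc1cc(CNC(=S)NCC(COC(=O)C(C)(C)C)Cc2ccc(C(C)(C)C)cc2)c(Br)cc1O` and compound 2 `COc1cc(CNC(=S)NCC(COC(=O)C(C)(C)C)Cc2ccc(C)c(C)c2)c(Br)cc1O` share one core; compound 3 `COc1cc(CNC(=S)NC(CCc2ccc(C(C)(C)C)cc2)COC(=O)C(C)(C)C)cc(Cl)c1O` and the unmeasured compound 4 `COc1cc(CNC(=S)NC(CCc2ccc(C)c(C)c2)COC(=O)C(C)(C)C)cc(Cl)c1O` share another. In an assay on CHO cells for displacement of a labelled ligand from transient receptor potential cation channel subfamily V member 1 (Rattus norvegicus) (a higher number here means a weaker inhibitor, a lower number a stronger inhibitor), compound 1 gives 12.8 nM, compound 2 gives 19.9 nM, and compound 3 gives 122 nM. The difference between the two cores is not broken down here; the numbers show compound 3 sitting well above both compound 1 and compound 2.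

The change from compound 1 to compound 2 is 3,4-dimethylphenyl in place of 4-(tert-butyl)phenyl on a saturated chain carbon, three bonds along the chain from an amide-type nitrogen and an oxygen next to a carbonyl group. It gave a 1.6-fold higher number from compound 1 to compound 2 (0.19 log units; within the scatter). Compound 4 carries the same kind of change on the other core: 3,4-dimethylphenyl in place of 4-(tert-butyl)phenyl on a saturated chain carbon, three bonds along the chain from an amide-type nitrogen. The surroundings differ: in compound 1 and compound 2 the carbon bearing the aryl group is three bonds along the chain from an amide-type nitrogen and an oxygen next to a carbonyl group, whereas in compound 3 and compound 4 it is three bonds along the chain from an amide-type nitrogen only.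

The step expected here is a 1.5-fold higher number from compound 3 to compound 4 (0.17 log units; within the scatter), close in size to the earlier one. Among the compounds with values here, this rests on the single precedent, because a 1.6-fold higher number from compound 1 to compound 2 (0.19 log units; within the scatter) was small, and on compound 3 starting weaker at 122 nM. With one precedent on a different core, the range is kept wide. Compound 4 is estimated at 180 nM, between 80 nM and 400 nM.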

Compound 4, inhibition constant: 86 nM
Compound 4: the middle estimate sits 2.1-fold (0.32 log units) above what was measured; measured number inside the range.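

In this assay, 3,4-dimethylphenyl in place of 4-(tert-butyl)phenyl on the second core gives a 1.4-fold lower number from compound 3 to compound 4 (0.15 log units; within the scatter) and so leaves the binding number within the scatter on this core as well. The two steps cannot be told apart: the same change on two cores in this assay, a 1.6-fold higher number (0.19 log units; within the scatter) from compound 1 to compound 2 and a 1.4-fold lower number (0.15 log units; within the scatter) from compound 3 to compound 4, 2.2-fold (0.34 log units) apart, within the scatter of two such steps. This shows that, in these two pairs, the exchange carries from one core to the other without a measurable change in this assay, but with both steps inside the scatter it shows no real gain or loss on either core, and two pairs give no rule for other cores.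

The compounds shown leave open whether the same tolerance extends to other aryl groups, such as unsubstituted phenyl or 4-chlorophenyl, or to a longer chain in place of 2-(3,4-dimethylphenyl)ethyl. They also leave open how much of the gap between the two cores belongs to the bromine and chlorine substituents and how much to the chain, and whether the exchange would behave alike with an amide in place of the ester.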